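A few compounds are considered here, and "the series" means these few. Any claim that something is new, unique, unknown or untested is made for them only; others in the source may bear on it.

Of the compounds shown here, two carry a number so far. In a functional assay on SH-SY5Y cells (Homo sapiens) for cytotoxicity, read by MTT assay, with a stated time of 72 h (a lower number here means a stronger inhibitor, a higher number a weaker inhibitor), compound 1 `O=C1c2c[n+]([O-])c3ccccc3c2C(=O)c2c1c1ccccc1n2Cc1cn([C@H]2O[C@H](CO)[C@@H](O)[C@H]2O)nn1` gives 1340 nM, while compound 2 `O=C1c2c[n+]([O-])c3ccccc3c2C(=O)c2c1c1ccccc1n2CCCCN1CCCCC1` gives 230 nM, the lower of the two, and the gap from compound 2 to compound 1 lies beyond the scatter. Compound 3 `O=C1c2c[n+]([O-])c3ccccc3c2C(=O)c2c1c1ccccc1n2CCCN1CCC(O)CC1` remains unmeasured. It differs from compound 2 in one place: 4-hydroxypiperidin-1-yl in place of (piperidin-1-yl)methyl on a saturated chain carbon, three bonds along the chain from an aromatic nitrogen. Among the measured compounds shown here, no measured pair shows this change, so its size is unknown; only a small step is expected in a 1.7-fold higher number from compound 2 to compound 3 (0.24 log units; within the scatter), if anything toward a higher number. Compound 3 is therefore estimated at 400 nM, with a range from 150 nM to 1100 nM.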

Compound 3, half-maximal inhibitory concentration: 130 nM
The estimate for compound 3 lay 3.1-fold (0.49 log units) above the measured number, and the stated range ends above it.
By their numbers in this assay, from the lowest: compounds 3 and 2 (each within the scatter of the next); then compound 1.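

In this assay, 4-hydroxypiperidin-1-yl in place of (piperidin-1-yl)methyl on this saturated chain carbon gives a 1.8-fold lower number from compound 2 to compound 3 (0.25 log units; within the scatter), so this position accepts the change without a step beyond the scatter. Read one bond further out, the same change is 4-(piperidin-1-yl)butyl to 3-(4-hydroxypiperidin-1-yl)propyl, so chain length and the hydroxy group change together. No measurement on hand accounts for this step. The compounds shown leave the chain length and the hydroxy group unseparated. They also leave open how a morpholine or a carboxylic acid would read on the same chain.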